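The source may hold more compounds than are shown below. What is called first, only, known or untested is meant among the compounds shown, and "the series" means these compounds.

Compound 1 `NC(=O)CCCN(Cc1cccc(C(N)=O)c1)C[C@H]1O[C@@H](n2cnc3c(N)ncnc32)[C@H](O)[C@@H]1O` and compound 2 `NC(=O)c1cccc(CN(CCCC(=O)O)C[C@H]2O[C@@H](n3cnc4c(N)ncnc43)[C@H](O)[C@@H]2O)c1` share one core and differ in a single place, compound 2 carrying a hydroxy in place of the amino on a carbonyl carbon. In an assay on cells for inhibition of Nicotinamide N-methyltransferase (Homo sapiens), with stated times of 10 min and 30 min (on this read-out higher numbers stand for weaker inhibition and lower numbers for stronger inhibition), compound 1 gives > 250000 nM, which is a limit of the assay and not a number. In this assay compound 2 gives > 250000 nM, also a limit of the assay rather than a number. The step that the two limits leave unreadable from compound 1 to compound 2 cannot be read in size or direction since (the limit of > 250000 nM in this assay, at which 2 of the 2 values shown sit). On the numbers shown, compound 2 therefore stands only at a limit, and the one further value shown is a limit as well. Compound 3 `Nc1ncnc2c1ncn2[C@@H]1O[C@H](CN(CCCC(=O)O)Cc2ccc3ccccc3c2)[C@@H](O)[C@H]1O` differs from compound 2 by naphthalen-2-yl in place of 3-carbamoylphenyl on a saturated chain carbon bound to an amine nitrogen. For the measured compounds named here, no measured step bears on this change: the single measured step ends in two limits and gives no size, so from the data no direction beyond the scatter can be expected in this assay. Compound 3 is expected to give an estimated 100000 nM in this assay, with a range from 10000 nM to 250000 nM. This estimate means an expected step of an at least 2.5-fold lower number from compound 2 to compound 3 (0.39 log units; beyond the scatter).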

Compound 3, half-maximal inhibitory concentration: > 250000 nM
Compound 3 ended at the assay's limit; the forecaster's own chance of this, stated with the estimate: 60%; at least 2.5-fold (0.39 log units) between middle value and limit.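

In this assay compound 3 gives > 250000 nM, which is a limit of the assay and not a number. For the compounds shown here, no step from compound 2 to compound 3 can be read in size or direction: the limit of > 250000 nM in this assay, at which 3 of the 3 values shown sit. The compounds shown leave open how strongly any of them inhibits and whether either change on the shared core alters the read-out.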